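A Chlorinated Chain Replaces a Hydroxy Group

The compounds below may be only part of what the source reports. "The series", "measured", "known", "first", "only" and "open" are said of these compounds alone.

In a functional assay on KYSE-450 cells (Homo sapiens) for inhibition, read by MTT assay, with a stated time of 48 h (a higher number here means a weaker inhibitor, a lower number a stronger inhibitor), compound 1 `C/C=C/C=C/C(=O)N(Cc1ccc(OC)c(O)c1)c1cc(OC)c(OC)c(OC)c1` gives 180 nM while compound 2 `COc1ccc(CN(C(=O)CO)c2cc(OC)c(OC)c(OC)c2)cc1O` gives 370 nM as its reading. Among the measured compounds shown here, compound 2 therefore holds the higher of the only two numbers available, which makes it the weaker inhibitor of the pair. For the measured compounds named here, the single measured step is a 2.1-fold higher number from compound 1 to compound 2 (0.31 log units; beyond the scatter) and it is modest. It placed hydroxymethyl where penta-1,3-dien-1-yl stood on a carbonyl carbon.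

Compound 3 `COc1ccc(CN(C(=O)CCCCCl)c2cc(OC)c(OC)c(OC)c2)cc1O` has not yet been measured. Its difference from compound 2 is 3-chloropropyl in place of hydroxy on a saturated chain carbon bound to a carbonyl carbon and in words, 3-chloropropyl stands in place of hydroxy on a saturated chain carbon bound to a carbonyl carbon. Going by the values given here, only one step bears on this change, so the support is thin. Compound 3 loses the hydroxy, and compound 1 at 180 nM carries none on its chain either, so a move back toward that number seems likelier than a further rise. The expected change is a 2.2-fold lower number from compound 2 to compound 3 (0.34 log units; beyond the scatter) and that would be another modest step, this time toward a lower number. For compound 3 the estimated value in this assay is 170 nM with 60 nM and 500 nM as the ends of the expected range.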

Compound 3, half-maximal inhibitory concentration: 770 nM
For compound 3 the middle estimate is 4.5-fold (0.66 log units) below the measured one, outside the stated range (above it).
By their numbers in this assay, from the lowest: compound 1; then compound 2; then compound 3.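

Taking away the hydroxy did not bring the number back toward that of compound 1: in this assay, 3-chloropropyl in place of hydroxy gives a 2.1-fold higher number from compound 2 to compound 3 (0.32 log units; beyond the scatter) and leaves compound 3 the weakest inhibitor of the three. The gap to the best compound of the set is wider still, with 4-chlorobutyl in place of penta-1,3-dien-1-yl giving a 4.3-fold higher number from compound 1 to compound 3 (0.63 log units; beyond the scatter) on the same carbonyl carbon, so the two chains without a hydroxy stand at opposite ends of this short series and hydroxymethyl falls between them. Lacking a hydroxy is therefore not enough on its own to give a low number here, and nothing available explains why the chlorinated chain gives the highest number.

These three compounds cannot separate the effect of the chlorine from that of the chain itself, since a plain butyl chain or a 4-hydroxybutyl chain would be needed to pull those two apart. Going by these compounds, it also stays open how an amine or a carboxylic acid at the end of the chain would compare, and whether a saturated pentyl chain would keep the number of compound 1 at 180 nM or lose it.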